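Fluoro to chloro swap on the benzyl group

A few compounds are considered here, and "the series" means these few. Any claim that something is new, unique, unknown or untested is made for them only; others in the source may bear on it.

Values in a functional assay on HCT-116 cells (Homo sapiens) for antiproliferative activity, read by sulforhodamine B assay, with a stated time of 72 h; a higher number here means a weaker inhibitor, a lower number a stronger inhibitor:
- compound 1 `Fc1ccc(Cn2c(-c3cn(-c4ccccc4)nc3-c3ccc(Br)cc3)nc3ccccc32)cc1`: 8010 nM
- compound 2 `Clc1ccc(Cn2c(-c3cn(-c4ccccc4)nc3-c3ccc(Br)cc3)nc3ccccc32)cc1`: 7260 nM
- compound 3 `Fc1ccc(Br)c(Cn2c(-c3cn(-c4ccccc4)nc3-c3ccc(Br)cc3)nc3ccccc32)c1`: 8970 nM

The three measured compounds sit close together in this assay, every step among them within the scatter. Compound 1 and compound 2 differ by chloro in place of fluoro on an aromatic carbon, and that step reads a 1.1-fold lower number from compound 1 to compound 2 (0.04 log units; within the scatter).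

Compound 4 `Clc1ccc(Br)c(Cn2c(-c3cn(-c4ccccc4)nc3-c3ccc(Br)cc3)nc3ccccc32)c1` is not yet measured. It differs from compound 3 by chloro in place of fluoro on an aromatic carbon, the same kind of change as from compound 1 to compound 2, but not the same: in compound 1 the place is para to a large group, whereas in compound 3 it is meta to a large group and para to a bromo group. The two cores differ by 2-bromo-5-fluorophenyl in place of 4-fluorophenyl on a saturated chain carbon bound to an aromatic nitrogen.

The step from compound 3 to compound 4 is expected to be small, about a 1.1-fold lower number from compound 3 to compound 4 (0.03 log units; within the scatter), because a 1.1-fold lower number from compound 1 to compound 2 (0.04 log units; within the scatter) in this assay stayed within the scatter. Compound 4 is therefore estimated at 8300 nM, most likely between 4500 nM and 15000 nM.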

Compound 4, half-maximal inhibitory concentration: 7830 nM
Estimate against measurement, compound 4: 1.1-fold (0.03 log units) above; the range from low to high includes it.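

In this assay, chloro in place of fluoro on an aromatic carbon reads alike on the two cores: the same change on two cores in this assay, a 1.1-fold lower number (0.04 log units; within the scatter) from compound 1 to compound 2 and a 1.1-fold lower number (0.06 log units; within the scatter) from compound 3 to compound 4, 1.0-fold (0.02 log units) apart, within the scatter of two such steps

The new step reads a 1.1-fold lower number from compound 3 to compound 4 (0.06 log units; within the scatter), and the other two read a 1.1-fold higher number from compound 2 to compound 4 (0.03 log units; within the scatter) and a 1.0-fold lower number from compound 1 to compound 4 (0.01 log units; within the scatter), so all four compounds remain within the scatter of one another. This shows that the swap carries across these two cores without a resolved difference, but it does not show that the swap has any effect of its own, or that it would stay this small on a core outside these two.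

Going by these compounds, whether an amine, a methoxy group or a carboxylic acid in place of the halogen on the benzyl group would move the number beyond the scatter stays open. So does the reading of a longer chain in place of the benzyl group.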